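A few compounds are considered here, and "the series" means these few. Any claim that something is new, unique, unknown or untested is made for them only; others in the source may bear on it.

Compound 1 `O=C(Nc1cccc(Cl)c1)c1cc(Cl)ccc1O`: 2460 nM
Compound 2 `O=C(Nc1cccc(F)c1)c1cc(Cl)ccc1O`: 3630 nM

In a toxicity assay on Vero C1008 cells (Chlorocebus sabaeus) for cytotoxicity, read by MTT assay, with a stated time of 48 h (a higher number here means that more compound is tolerated, a lower number that less compound is tolerated), compound 2 gives 3630 nM, and compound 1 gives 2460 nM. The two lie within the scatter of each other: the single measured step, a 1.5-fold higher number from compound 1 to compound 2 (0.17 log units; within the scatter), is too small to count as a real change, so compound 2 stands level with compound 1 on the numbers shown.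

Compound 3 `O=C(Nc1cccc(O)c1)c1cc(Cl)ccc1O` is not yet measured in this assay. It differs from compound 2 in one place: hydroxy in place of fluoro on an aromatic carbon. Among the compounds with values here, the only measured step, a 1.5-fold higher number from compound 1 to compound 2 (0.17 log units; within the scatter), swaps one halogen for another at this same position and bears on the present change only loosely, since a hydroxy group is not a halogen. With nothing else to go on, the step is expected to stay within the scatter, as a 1.0-fold lower number from compound 2 to compound 3 (0.02 log units; within the scatter). Compound 3 is therefore estimated at 3500 nM, between 1500 nM and 9000 nM.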

Compound 3, half-maximal cytotoxic concentration: > 100000 nM
Compound 3: only a limit was reported (the forecaster's own chance of this, stated with the estimate: 10%); middle value at least 28-fold (1.45 log units) from the limit.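

In this assay, this aromatic carbon, which showed no real change when one halogen replaced the other, turns out to be sensitive to the group it carries: hydroxy in place of fluoro gives an at least 27-fold higher number from compound 2 to compound 3 (1.44 log units; beyond the scatter), and hydroxy in place of chloro gives an at least 40-fold higher number from compound 1 to compound 3 (1.60 log units; beyond the scatter). Both steps lie beyond the scatter, so leaving the halogens for hydroxy counts for far more here than exchanging chloro and fluoro did. The value of compound 3 is a limit and not a number: the limit of > 100000 nM in this assay, at which 1 of the 3 values shown sits.

The compounds shown leave open whether this large step belongs to hydroxy alone or would also come with an amine or a methoxy group at the same place. They also leave open whether hydroxy would give such a step elsewhere on this ring.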